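This account rests on a few compounds, and the source may have more. Where it says the series, first, only, none or still open, it means among the compounds named here.

Measured compounds:
- compound 1 `O=C(CCCCCCc1ccccc1)c1ncc(-c2ccccc2F)o1` — 110 nM
- compound 2 `COc1ccccc1-c1cnc(C(=O)CCCCCCc2ccccc2)o1` — 400 nM
- compound 3 `O=C(O)c1ccc(-c2cnc(C(=O)CCCCCCc3ccccc3)o2)cc1` — 60 nM

In an assay (Rattus norvegicus) for inhibition of Fatty-acid amide hydrolase 1 (Homo sapiens) (a higher number here means a weaker inhibitor, a lower number a stronger inhibitor), compound 3 gives the lowest of the three numbers, but the step of a 1.8-fold lower number from compound 1 to compound 3 (0.26 log units; within the scatter) lies within the scatter, so compound 3 is not set apart from compound 1; only a 6.7-fold lower number from compound 2 to compound 3 (0.82 log units; beyond the scatter) lies beyond the scatter. Within the data shown here, the group on the shared core of compound 3 is exchanged once more in compound 4 `Cc1cccnc1-c1cnc(C(=O)CCCCCCc2ccccc2)o1`, which is not yet measured. 3-methylpyridin-2-yl in place of 4-carboxyphenyl on an aromatic carbon The steps that bear on this change are those that swap the same group: a 1.8-fold lower number from compound 1 to compound 3 (0.26 log units; within the scatter), a 6.7-fold lower number from compound 2 to compound 3 (0.82 log units; beyond the scatter) and, between the two measured groups without the carboxylic acid, a 3.6-fold higher number from compound 1 to compound 2 (0.56 log units; beyond the scatter). The entering 3-methylpyridin-2-yl, like 2-fluorophenyl and 2-methoxyphenyl, lacks the carboxylic acid of 4-carboxyphenyl, so a number between those of compound 1 and compound 2 is expected, a modest rise of a 2.7-fold higher number from compound 3 to compound 4 (0.43 log units; beyond the scatter) in this assay. For compound 4 the estimate is 160 nM, with a range from 50 nM to 500 nM.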

Compound 4, inhibition constant: 15 nM
Beside the measured number, compound 4's estimate is 11-fold (1.03 log units) above it; the whole stated range lies above it.
By their numbers in this assay, from the lowest: compound 4; then compounds 3 and 1 (each within the scatter of the next); then compound 2.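

In this assay, 3-methylpyridin-2-yl on the aromatic carbon next to the ring oxygen separates from all three earlier groups: a 4.0-fold lower number from compound 3 to compound 4 (0.60 log units; beyond the scatter), a 7.3-fold lower number from compound 1 to compound 4 (0.87 log units; beyond the scatter) and a 27-fold lower number from compound 2 to compound 4 (1.43 log units; beyond the scatter). The carboxylic acid of 4-carboxyphenyl is therefore not needed for the lowest number in this set, and absence of that acid does not place a compound with compound 1 and compound 2. No data here explain this gain.

The compounds shown do not separate the contribution of the ring nitrogen from that of the methyl, which a pyridine ring without the methyl and a methylphenyl group would address. Also open, on these data alone, is whether a carboxylic acid on the methylpyridine ring would lower the number further or raise it.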